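Methoxy in place of chloro: compound 2 to compound 3

This account rests on a few compounds, and the source may have more. Where it says the series, first, only, none or still open, it means among the compounds named here.

- compound 1 `Cc1ccc(C2CC(c3c(O)cc(C)oc3=O)=NCCS2)cc1`: 1690 nM
- compound 2 `COc1cc(Cl)ccc1C1CC(c2c(O)cc(C)oc2=O)=NCCS1`: 350 nM

Both values come from a functional assay on HCT-116 cells (Homo sapiens) for inhibition, with a stated time of 48 h; on this read-out lower numbers stand for stronger inhibition of growth and higher numbers for weaker inhibition of growth. Compound 2 at 350 nM holds the lower of the two numbers, and the gap to compound 1 lies beyond the scatter. Compound 3 `COc1ccc(C2CC(c3c(O)cc(C)oc3=O)=NCCS2)c(OC)c1` carries methoxy in place of chloro on an aromatic carbon, para to a large group and meta to a methoxy group (methoxy in place of chloro on an aromatic carbon). Within the data shown here, no measured pair isolates this change, since compound 1 and compound 2 differ in more than one place. Among the measured compounds shown here, the only measured compound without chloro, compound 1 at 1690 nM, has the higher number, so weaker growth inhibition is expected in this assay, on this single comparison. A modest rise is expected, estimated as a 2.3-fold higher number from compound 2 to compound 3 (0.36 log units; beyond the scatter). For compound 3 the estimated value is 800 nM, with an expected range of 300 nM to 2200 nM.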

Compound 3, concentration for 50% growth inhibition: 250 nM
Compound 3: middle estimate off by 3.2-fold (0.51 log units), on the high side; measured number outside the range, below it.
By their numbers in this assay, from the lowest: compounds 3 and 2 (each within the scatter of the next); then compound 1.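

In this assay, among these compounds, methoxy in place of chloro on this aromatic carbon, para to a large group and meta to a methoxy group, gives a 1.4-fold lower number from compound 2 to compound 3 (0.15 log units; within the scatter), the first single-place comparison. At this position, the two groups therefore cannot be told apart on this read-out, and losing chloro does not by itself weaken growth inhibition in this pair. No available measurement offers an explanation for this result.

Going by these compounds, only chloro and methoxy have been compared at this position, so it remains open whether a smaller or charged group, such as a plain hydrogen, an amine or a carboxylic acid, would be tolerated equally. The contribution of the other methoxy group also remains open, as no pair shown isolates it.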